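The source may hold more compounds than are shown below. What is called first, only, known or untested is meant among the compounds shown, and "the series" means these compounds.

Two compounds built on a shared core have been examined in an ADME assay on HEK-293T cells (Homo sapiens) for cytotoxicity, read by CCK-8 assay, with a stated time of 48 h; a lower number here means that less compound is tolerated, a higher number that more compound is tolerated. Compound 1 `Cn1cc(SCC(=O)Nc2ccc(Cl)cc2)c2ccccc21` carries a chloro group on its aniline ring. In this assay compound 1 gives > 100000 nM, which is a limit of the assay rather than a measured number. Compound 2 `COc1cccc2c(SCC(=O)Nc3ccc(Cl)c(Cl)c3)c[nH]c12` carries a methoxy group on the fused ring and two chloro groups on the aniline. In this assay compound 2 gives > 100000 nM, again a limit and not a number. Among the compounds with values here, compound 2 therefore stands at the limit of > 100000 nM in this assay, at which 2 of the 2 values shown sit, with no compound showing a numerical value that could be ranked against it.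

Compound 3 `O=C(CSc1c[nH]c2c(Cl)cccc12)Nc1ccc(Cl)c(Cl)c1` differs from compound 2 in one place: chloro in place of methoxy on an aromatic carbon. Within the data shown here, no step between two measured compounds is available, so the effect of this change cannot be read from the data at hand. The step expected here is a step that the limit leaves unreadable from compound 2 to compound 3, which is nothing beyond the usual scatter. Compound 3 is accordingly expected at about 130000 nM, within a range from 40000 nM to 400000 nM, and the outcome will most likely again be reported as a limit.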

Compound 3, half-maximal cytotoxic concentration: 49100 nM
For compound 3 the middle estimate is 2.6-fold (0.42 log units) above the measured one; the measured number falls inside the stated range.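

Within the data shown here, compound 3 is the first compound here to give a number rather than a limit in this assay, so at this place, on an aromatic carbon ortho to a fused ring, the result is no longer confined to a limit. Chloro in place of methoxy gives an at least 2.0-fold lower number from compound 2 to compound 3 (0.30 log units; that floor lies within the scatter), and this is only a floor, which does not by itself separate the two compounds beyond the usual scatter. On these data alone, the true size of the change stays unknown, and the comparison is bounded on one side by a limit: the limit of > 100000 nM in this assay, at which 2 of the 3 values shown sit.

The compounds shown leave open whether an amine, a fluoro group or a carboxylic acid at this place would also give a number. They also leave open whether the same exchange would give a similar result with a single chloro group on the aniline ring.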